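This account rests on a few compounds, and the source may have more. Where it says the series, first, only, none or still open, it means among the compounds named here.

Compound 1 `C/C(=C\c1ccc(Cc2cncs2)cc1)C(=O)O` was tested in a functional assay on the whole organism (blood) for inhibition, with Rattus norvegicus as the target, with a stated time of 1 h, at a dose of 1 mg/kg by the oral route (a higher number here means more inhibition at the dose given (going by the name of the read-out), a lower number less inhibition), where compound 1 gave 44%. Among the two measured compounds, compound 1 stands highest; its nearest neighbour is compound 2 `O=C(O)/C=C/c1ccc(Cc2cncs2)cc1`, which in this assay gave 39%, and the only measured step, a number 5 percentage points lower from compound 1 to compound 2 (within the scatter), lies within the scatter. Compound 3 `C/C(=C\c1ccc(Cc2cccnc2)cc1)C(=O)O` has not yet been measured. It differs from compound 1 in one place: pyridin-3-yl in place of 1,3-thiazol-5-yl on a saturated chain carbon bound to an aromatic carbon. Among the measured compounds shown here, the measured step from compound 1 to compound 2 changes the acid-bearing chain on the aromatic ring, not the heteroaryl group, so it does not bear directly on this change; no measured pair shows the effect of exchanging the heteroaryl ring. Lacking any such step, the account expects no step beyond the scatter, estimating a number 4 percentage points lower from compound 1 to compound 3 (within the scatter). Compound 3 is thus estimated at 40%, with a range from 15% to 65%.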

Compound 3, a percentage reported as inhibition, in the whole organism at one dose (the size of the read-out at that dose, not a potency): 71%
Estimate against measurement, compound 3: 31 percentage points below; the whole stated range lies below it.
By their numbers in this assay, from the lowest: compounds 2 and 1 (each within the scatter of the next); then compound 3.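

In this assay the group on the saturated chain carbon bound to an aromatic carbon proves to matter: pyridin-3-yl in place of 1,3-thiazol-5-yl gives a number 27 percentage points higher from compound 1 to compound 3 (beyond the scatter) in the read-out, the only step shown that lies beyond the scatter. The earlier change to the acid-bearing chain gave a number 5 percentage points lower from compound 1 to compound 2 (within the scatter) and so did not separate the compounds, which leaves the heteroaryl group as the one place shown where a single change moves the number clearly. Nothing shown gives a reason for this step.

On these data alone, whether pyridin-3-yl would give a step of like size on the 2-carboxyethenyl chain of compound 2 remains open. So does the outcome with a plain phenyl ring or an amine on the same saturated chain carbon.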